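This account rests on a few compounds, and the source may have more. Where it says the series, first, only, none or still open, it means among the compounds named here.

Measured so far in an ADME assay on the whole organism for cytotoxicity, with Artemia salina as the target, with a stated time of 24 h; on this read-out lower numbers stand for an effect already at smaller amounts and higher numbers for an effect only at larger amounts of compound:
compound 1 `Cc1ccc(S(=O)(=O)NC(=O)Nc2ccccc2C(=O)/C=C/c2ccccc2)cc1`: 25 ug/mL
compound 2 `Cc1ccc(/C=C/C(=O)c2ccccc2NC(=O)NS(=O)(=O)c2ccc(C)cc2)cc1`: 15.3 ug/mL
compound 3 `COc1ccc(/C=C/C(=O)c2ccccc2NC(=O)NS(=O)(=O)c2ccc(C)cc2)cc1OC`: 12.9 ug/mL

Compound 3 carries the lowest of the three numbers, yet its gaps to the others, a 1.2-fold lower number from compound 2 to compound 3 (0.07 log units; within the scatter) and a 1.9-fold lower number from compound 1 to compound 3 (0.29 log units; within the scatter), both lie within the scatter, so the three compounds cannot be told apart in this assay. Compound 4 `Cc1ccc(S(=O)(=O)NC(=O)Nc2ccccc2C(=O)/C=C/c2ccccc2O)cc1` differs from compound 3 in one place: 2-hydroxyphenyl in place of 3,4-dimethoxyphenyl on a double-bonded chain carbon bound to a double-bonded chain carbon. For the measured compounds named here, the steps that bear on this change are those that also swapped the group on the double-bonded chain carbon, a 1.9-fold lower number from compound 1 to compound 3 (0.29 log units; within the scatter) and a 1.2-fold lower number from compound 2 to compound 3 (0.07 log units; within the scatter), and neither moved the number beyond the scatter. The number for compound 4 is therefore expected to shift by only a 1.4-fold higher number from compound 3 to compound 4 (0.14 log units; within the scatter), giving an estimated 18 ug/mL with a range from 9 ug/mL to 36 ug/mL.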

Compound 4, concentration for half-maximal effect: 32.3 ug/mL
Compound 4: the middle estimate sits 1.8-fold (0.25 log units) below what was measured; measured number inside the range.
By their numbers in this assay, from the lowest: compounds 3, 2, 1 and 4 (each within the scatter of the next, the first and the last beyond it).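

On the double-bonded chain carbon bound to a double-bonded chain carbon, 2-hydroxyphenyl produces the first differences in this assay that pass the scatter, both modest (a 2.5-fold higher number from compound 3 to compound 4 (0.40 log units; beyond the scatter); a 2.1-fold higher number from compound 2 to compound 4 (0.32 log units; beyond the scatter)). Against the plain phenyl, however, the added hydroxy cannot be told apart (a 1.3-fold higher number from compound 1 to compound 4 (0.11 log units; within the scatter)), so the separation holds only against the 3,4-dimethoxyphenyl and 4-methylphenyl compounds. Nothing available accounts for this difference. As far as these compounds go, it remains open whether the hydroxy group matters apart from its place on the ring, and how an amine or a carboxylic acid on this ring would compare.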